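Removing the methylsulfonyl group from compound 3

This account rests on a few compounds, and the source may have more. Where it says the series, first, only, none or still open, it means among the compounds named here.

Compound 3 `CS(=O)(=O)c1ccc(C(=O)Nc2ccc(Cl)c(-c3nnc4c(Cl)cccn34)c2)c(Cl)c1` is the starting point here. In a functional assay on MDA-MB-231 cells (Homo sapiens) for antiproliferative activity, read by MTT assay, with stated times of 72 h and 4 h (on this read-out higher numbers stand for weaker inhibition and lower numbers for stronger inhibition), compound 3 gives 37200 nM, which stands alongside the value of compound 2 within the usual scatter. Compound 2 `O=C(Nc1ccc(Cl)c(-c2nnc3c(Cl)cccn23)c1)c1ccc(F)cc1Cl` carries a fluoro group instead of the methylsulfonyl group, and in this assay compound 2 gives 75000 nM. Compound 1 `O=C(Nc1ccc(Cl)c(-c2nnc3c(Cl)cccn23)c1)c1ccc(C(F)(F)F)cc1Cl` carries a trifluoromethyl group instead. In this assay compound 1 reaches only a limit of the measurement, > 100000 nM, that is the limit of > 100000 nM in this assay, at which 1 of the 3 values shown sits. Compound 4 `O=C(Nc1ccc(Cl)c(-c2nnc3c(Cl)cccn23)c1)c1ccccc1Cl` has not yet been measured; it differs from compound 3 by hydrogen in place of methylsulfonyl on an aromatic carbon. For the measured compounds named here, two measured steps bear on this change: an at least 2.6-fold lower number from compound 1 to compound 3 (0.42 log units; beyond the scatter) and a 2.0-fold lower number from compound 2 to compound 3 (0.30 log units; within the scatter). Both show that bringing in methylsulfonyl lowered the number by a modest amount at most, so taking it away is expected to raise it by a similar amount, giving the expected step of a 2.2-fold higher number from compound 3 to compound 4 (0.33 log units; beyond the scatter). Compound 4 is therefore expected to give about 80000 nM in this assay, within a range from 30000 nM to 200000 nM.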

Compound 4, half-maximal inhibitory concentration: 59900 nM
For compound 4 the middle estimate is 1.3-fold (0.13 log units) above the measured one; the range from low to high includes it.
By their numbers in this assay, from the lowest: compounds 3, 4 and 2 (each within the scatter of the next). At a limit, above all of these: compound 1.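

With only hydrogen at this position, para to a large group, this assay shows a 1.6-fold higher number from compound 3 to compound 4 (0.21 log units; within the scatter) and a 1.3-fold lower number from compound 2 to compound 4 (0.10 log units; within the scatter). Methylsulfonyl, fluoro and hydrogen therefore cannot be told apart here, so taking the group away altogether brings no measurable change, and a substituent at this position is not needed to keep this level of activity. The trifluoromethyl comparison gives only an at least 1.6-fold lower number from compound 1 to compound 4 (0.22 log units; that floor lies within the scatter), a floor, since one end of it is a limit of the assay and not a number: the limit of > 100000 nM in this assay, at which 1 of the 4 values shown sits.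

As far as these compounds go, whether an amine or a carboxylic acid at this position would move the number beyond the scatter remains open. Also open, from the compounds shown here alone, is whether any change at this position could bring these compounds, all with high numbers, to much stronger inhibition.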